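The compounds below may be only part of what the source reports. "The series", "measured", "known", "first", "only" and "open" are said of these compounds alone.

Compound 1 `CCCc1nc(C)c2c(C)nn(CC)c(=O)n12` stands only at a limit in a functional assay for inhibition, with Homo sapiens as the target; on this read-out lower numbers stand for stronger inhibition and higher numbers for weaker inhibition. In this assay compound 1 gives > 48000 nM, which is a limit of the assay and not a number. Compound 2 `CCCc1nc(C)c2c(C)nnc(SC)n12` gives > 48000 nM, again a limit. Compound 3 `CCCc1nc(C)c2cnn(CC)c(=O)n12` gives > 48000 nM, also a limit. The step that the two limits leave unreadable from compound 1 to compound 3 cannot be sized, since every value shown sits at the limit of > 48000 nM in this assay, at which 3 of the 3 values shown sit.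

Compound 4 `CCCc1nc(C)c2c(C)nn(CC(O)CO)c(=O)n12` differs from compound 1 by 1,2-dihydroxyethyl in place of methyl on a saturated chain carbon bound to an aromatic nitrogen. Going by the values given here, no measured step bears a readable size on this change, so no direction can be drawn from the numbers. Compound 4 is therefore expected to remain near the limit, at an estimated 48000 nM with a range from 10000 nM to 200000 nM. This expectation amounts to a step of a number no higher from compound 1 to compound 4 (the limit leaves the size open), none beyond the scatter.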

Compound 4, half-maximal inhibitory concentration: > 48000 nM
Compound 4 gave a limit, no number; the forecaster's own chance of this, stated with the estimate: 80%; the middle value lies on the limit itself.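

No new step can be read from compound 1 to compound 4, since both stand only at a limit: the limit of > 48000 nM in this assay, at which 4 of the 4 values shown sit.

The compounds shown leave open whether any change to the shared core gives a readable value in this assay.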